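Propyl to hydrogen on an aromatic nitrogen

This account rests on a few compounds, and the source may have more. Where it says the series, first, only, none or still open, it means among the compounds named here.

Values in a toxicity assay on THP-1 cells (Homo sapiens) for inhibition (on this read-out lower numbers stand for higher toxicity in this test and higher numbers for lower toxicity in this test), for the measured compounds:
Compound 1 `CCCC(=O)Nc1ncc(-c2ccc(OC)cc2)n1C` gives > 100000 nM as a limit
Compound 2 `CCC(=O)Nc1ncc(-c2ccc(OC)cc2)n1C` gives > 100000 nM as a limit
Compound 3 `CCCn1c(-c2ccc(OC)cc2)cnc1NC(=O)c1ccc(F)cc1` gives > 100000 nM as a limit

Compound 3 stands at > 100000 nM as a limit of the assay and not a number. The data so far offer the limit of > 100000 nM in this assay, at which 3 of the 3 values shown sit, and no exact value for any compound. Going on to compound 4 `COc1ccc(-c2cnc(NC(=O)c3ccc(F)cc3)[nH]2)cc1` means one change, hydrogen in place of propyl on an aromatic nitrogen with hydrogen in place of propyl on an aromatic nitrogen. Within the data shown here, the one measured step is a step that the two limits leave unreadable from compound 1 to compound 2 and it lies on the amide chain, a different place in the molecule. Among the measured compounds shown here, no measured step therefore gives a size for this change, and the expectation rests on the shared limit alone. The estimated move is a number no higher from compound 3 to compound 4 (the limit leaves the size open) in this assay with no step beyond the scatter expected in either direction. For compound 4 the estimate is 100000 nM with an expected range from 30000 nM to 100000 nM on this read-out.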

Compound 4, half-maximal cytotoxic concentration: > 100000 nM
Compound 4 was reported as a limit; the forecaster's own chance of this, stated with the estimate: 85%; the middle value lies on the limit itself.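

In this assay compound 3 and compound 4 are both reported only as limits, so the step between them, hydrogen in place of propyl on an aromatic nitrogen, cannot be read. The compounds shown leave open what exact toxicity any of them has, and whether any change alters it, since all share one limit: the limit of > 100000 nM in this assay, at which 4 of the 4 values shown sit.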